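The source may hold more compounds than are shown below. What is called first, only, known or untested is meant among the compounds shown, and "the series" means these compounds.

Compound 1 `NC(=O)c1c(NC(=O)c2ccc(Cl)cc2)sc2c1CCN(C(=O)c1ccccc1)C2` gives 42.5% in an ADME assay on RAW264.7 cells (Mus musculus) for cytotoxicity, read by MTT assay, with a stated time of 48 h, tested at 50 uM; a lower number here means less inhibition, a higher number more inhibition at the concentration tested (going by the name of the read-out). Compound 2 `CC(=O)N1CCc2c(sc(NC(=O)c3ccc(Cl)cc3)c2C(N)=O)C1` gives 38.4% in this assay, and compound 3 `CC(C)(C)OC(=O)N1CCc2c(sc(NC(=O)c3ccc(Cl)cc3)c2C(N)=O)C1` gives 37.3% in this assay; compound 3 stands lowest of the three numbers shown, with both gaps to the other compounds within the scatter. The steps that vary the group on the amine nitrogen in a ring, namely a number 4.1 percentage points lower from compound 1 to compound 2 (within the scatter), a number 5.2 percentage points lower from compound 1 to compound 3 (within the scatter) and a number 1.1 percentage points lower from compound 2 to compound 3 (within the scatter), all stay within the scatter. Compound 4 `NC(=O)c1c(NC(=O)c2ccc(Cl)cc2)sc2c1CCN(Cc1ccccc1)C2` differs from compound 3 by benzyl in place of tert-butoxycarbonyl on an amine nitrogen in a ring. The same nitrogen is varied again, so for compound 4 no step beyond the scatter is expected in this assay, that is a number 1.7 percentage points higher from compound 3 to compound 4 (within the scatter). Compound 4 is therefore estimated at 39%, with a range from 27% to 52%.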

Compound 4, a percentage reported as inhibition, at one concentration (the size of the read-out at that concentration, not a potency): 11.1%
The estimate for compound 4 lay 27.9 percentage points above the measured number; measured number below the stated range.
By their numbers in this assay, from the lowest: compound 4; then compounds 3, 2 and 1 (each within the scatter of the next).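

Among the compounds shown here, at the amine nitrogen in a ring, the acyl and carbamate groups of compounds 1, 2 and 3 read alike in this assay, so the earlier steps gave no sign that this position matters; benzyl does not read alike (a number 26.2 percentage points lower from compound 3 to compound 4 (beyond the scatter)), (a number 27.3 percentage points lower from compound 2 to compound 4 (beyond the scatter)), (a number 31.4 percentage points lower from compound 1 to compound 4 (beyond the scatter)). The benzoyl to benzyl step is the most telling: both groups carry an aromatic ring of carbon only, so that ring alone does not set compound 4 apart from compound 1.

Still open, going by these compounds, is how the free amine hydrogen, a simple ethyl chain or a phenethyl group on this nitrogen would read. No measurement shown bears on the reason for the drop.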